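A Second Chloro on the Shared Core

This account rests on a few compounds, and the source may have more. Where it says the series, first, only, none or still open, it means among the compounds named here.

Compound 1 `Cc1cc2nc(CCC3CCCCC3)[nH]c2cc1C`, compound 2 `Brc1ccc2[nH]c(CCC3CCCCC3)nc2c1` and compound 3 `Clc1ccc2[nH]c(CCC3CCCCC3)nc2c1` share one core and were tested in a functional assay on A549 cells (Homo sapiens) for inhibition, read by MTT assay, with a stated time of 120 h; on this read-out lower numbers stand for stronger inhibition and higher numbers for weaker inhibition. Compound 1 gives 11200 nM, compound 2 gives 13400 nM, and compound 3 gives 10900 nM. Among the measured compounds shown here, the only measured one-place step, a 1.2-fold lower number from compound 2 to compound 3 (0.09 log units; within the scatter), compares two halogens. Compound 3 has the lowest of the three numbers, yet all three lie within the scatter of one another, so none stands apart. Compound 4 `Clc1cc2nc(CCC3CCCCC3)[nH]c2cc1Cl` differs from compound 3 by chloro in place of hydrogen on an aromatic carbon, ortho to a chloro group. For the measured compounds named here, no measured step adds a second group to a halogen-bearing core, and compound 1, carrying two methyl groups, with 11200 nM does not separate from compound 3. The expected step is therefore a 1.1-fold lower number from compound 3 to compound 4 (0.04 log units; within the scatter), staying within the scatter. Compound 4 is estimated at 10000 nM, in a range from 4000 nM to 25000 nM.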

Compound 4, half-maximal inhibitory concentration: 11100 nM
The estimate for compound 4 lay 1.1-fold (0.05 log units) below the measured number, within the range that was stated.
By their numbers in this assay, from the lowest: compounds 3, 4, 1 and 2 (each within the scatter of the next).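

Putting chloro in place of hydrogen on an aromatic carbon, ortho to a chloro group, gives a 1.0-fold higher number from compound 3 to compound 4 (0.01 log units; within the scatter) and so in this assay the two compounds cannot be told apart. Among the compounds shown here, this is the first measured step that adds a group to a halogen-bearing core instead of exchanging one group for another, and here the added chloro makes no readable difference. Nothing measured here offers a reason for this result.

Going by these compounds, whether an amine or a carboxylic acid at this position would give a number beyond the scatter remains open.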